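The source may hold more compounds than are shown below. What is called first, only, known or untested is meant among the compounds shown, and "the series" means these compounds.

Compound 1 `CCCCCCCCCCCCn1c(N)c(N)c(=O)[nH]c1=O` gives 270 nM in a functional assay (mitochondria, heart) with Bos taurus as the target; a lower number here means a stronger inhibitor, a higher number a weaker inhibitor. Compound 2 `CCCCCCCCCCCCn1c(N)c(N)c(=O)n(C)c1=O` gives 240 nM in this assay. The change methyl in place of hydrogen on an aromatic nitrogen gave a 1.1-fold lower number from compound 1 to compound 2 (0.05 log units; within the scatter).

Compound 3 `CCCCCCCCCCCCn1c(=O)[nH]c(=O)c2[nH]c(O)nc21` gives 1600 nM in this assay. The difference between the core of compound 3 and the core of compound 1 is not broken down here.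

Compound 4 `CCCCCCCCCCCCn1c(=O)n(C)c(=O)c2[nH]c(O)nc21` is not yet measured. The change methyl in place of hydrogen on an aromatic nitrogen is the same kind of change as that from compound 1 to compound 2, but the place is part of a fused or bridged system of two rings, meta to a fused ring and para to a fused ring, where in compound 1 the place is meta to an amino group and para to an amino group. The estimate rests on a 1.1-fold lower number from compound 1 to compound 2 (0.05 log units; within the scatter), so the expected step is a 1.1-fold lower number from compound 3 to compound 4 (0.06 log units; within the scatter). Compound 4 is expected to give about 1400 nM, between 700 nM and 3000 nM.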

Compound 4, half-maximal inhibitory concentration: 850 nM
Compound 4: middle estimate off by 1.6-fold (0.22 log units), on the high side; measured number inside the range.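

In this assay, methyl in place of hydrogen on an aromatic nitrogen gave a 1.9-fold lower number from compound 3 to compound 4 (0.27 log units; within the scatter). The step on the core of compound 3 agrees with the step on the core of compound 1: the same change on two cores in this assay, a 1.1-fold lower number (0.05 log units; within the scatter) from compound 1 to compound 2 and a 1.9-fold lower number (0.27 log units; within the scatter) from compound 3 to compound 4, 1.7-fold (0.22 log units) apart, within the scatter of two such steps. Across these two cores the change can be carried as a step too small to read, but two pairs show no real gain or loss on either core and say nothing about any other core.

As far as these compounds go, whether an ethyl group or a carboxylic acid on this nitrogen would behave as methyl does remains open. Also open, from the compounds shown here alone, is whether a shorter chain in place of the long chain shared by all four compounds would keep these numbers.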